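The compounds below may be only part of what the source reports. "The series", "measured", "known", "first", "only" and "open" are said of these compounds alone.

Working notes on the series. The shared core appears with a cyclohexyl or cyclopentyl group on one nitrogen and an aryl substituent on the adjacent carbon. Compound 1 `Cc1ccc(-c2nc3cccnc3n2C2CCCCC2)cc1` carries a methylphenyl group, and in a functional assay on MDA-MB-231 cells (Homo sapiens) for cytotoxicity, read by MTT assay, with a stated time of 24 h (on this read-out lower numbers stand for stronger inhibition and higher numbers for weaker inhibition), compound 1 gives 7000 nM. Compound 3 `Cn1ccc2cc(-c3nc4cccnc4n3C3CCCC3)ccc21` carries a methylindolyl group, and in this assay compound 3 gives 90 nM. Compound 2 `c1ccc(Oc2ccc(-c3nc4cccnc4n3C3CCCC3)cc2)cc1` carries a phenoxyphenyl group. For compound 2 this assay reports only a limit, > 10000 nM, and not a number. This is the limit described as the limit of > 10000 nM in this assay, at which 1 of the 3 values shown sits. Among the numbers shown, compound 2 therefore stands at the weak end, with no measured value of its own to anchor it.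

Compound 4 `c1cncc(-c2ccc(-c3nc4cccnc4n3C3CCCC3)cc2)c1` differs from compound 2 in one place: pyridin-3-yl in place of phenoxy on an aromatic carbon. For the measured compounds named here, no measured pair in the set covers this change, so its size has to be judged from compound 2 alone. A step toward stronger inhibition, beyond the scatter, is expected from compound 2 to compound 4, estimated as an at least 3.3-fold lower number from compound 2 to compound 4 (0.52 log units; beyond the scatter), though with wide uncertainty since compound 2 sits at a limit. Compound 4 is expected to give 3000 nM in this assay, within 800 nM to 10000 nM.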

Compound 4, half-maximal inhibitory concentration: > 10000 nM
Compound 4 ended at the assay's limit (the forecaster's own chance of this, stated with the estimate: 30%); at least 3.3-fold (0.52 log units) between middle value and limit.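

Compound 2 and compound 4 both stand at a limit in this assay, so no step can be read between them: the limit of > 10000 nM in this assay, at which 2 of the 4 values shown sit.

The compounds shown leave open whether pyridin-3-yl and phenoxy differ at all in this assay.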